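The source may hold more compounds than are shown below. What is called first, only, known or untested is meant among the compounds shown, and "the series" means these compounds.

Of the compounds shown here, three built on one shared core have been tested in a functional assay on the whole organism (Tail, strain ICR) with Mus musculus as the target, in the tail flick test, with a stated time of 30 min, at a dose of 25 umol/kg by the oral route; a higher number here means a stronger effect of the compound at the dose given, a lower number a weaker effect. Compound 1, `N=C(N)NCCC[C@H](NC(=O)CN(c1nc(Cl)nc2[nH]cnc12)C1CC1)C(=O)OCc1ccccc1`, gives 23.2%. Compound 2, `O=C(O)CC[C@H](NC(=O)CN(c1nc(Cl)nc2[nH]cnc12)C1CC1)C(=O)O`, gives 26.8%, and compound 3, `CSCC[C@H](NC(=O)CN(c1nc(Cl)nc2[nH]cnc12)C1CC1)C(=O)O`, gives 20.4%. On these numbers compound 1 holds the second highest place of three, yet its gap to compound 3 and its gap to compound 2 both lie within the scatter, so the three results cannot be told apart.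

Compound 4, `NC(=O)C[C@H](NC(=O)CN(c1nc(Cl)nc2[nH]cnc12)C1CC1)C(=O)OCc1ccccc1`, differs from compound 1 only in the side chain: a group of 3 heavy atoms (1 carbon, 1 nitrogen, 1 oxygen; no ring) in place of a group of 6 heavy atoms (3 carbon, 3 nitrogen; no ring), on a saturated chain carbon, two bonds along the chain from an amide-type nitrogen and a carbonyl carbon. The group that leaves has no common name; the carbamoyl that enters sits on a saturated chain carbon, two bonds along the chain from an amide-type nitrogen and a carbonyl carbon.

For the measured compounds named here, the single measured step of the same kind, a swap within the side chain, is a number 6.4 percentage points lower from compound 2 to compound 3 (within the scatter), a change that stayed within the scatter. Compounds 1, 2 and 3 carry quite different side chains and still give numbers within the scatter of one another. The change from compound 1 to compound 4 is therefore expected to bring no step beyond the scatter in this assay, which is to say a number 0.2 percentage points lower from compound 1 to compound 4 (within the scatter). Compound 4 is estimated at 23%, with a range from 13% to 33%.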

Compound 4, a percentage reported as activity, at one dose (the size of the read-out at that dose, not a potency): 24.4%
Beside the measured number, compound 4's estimate is 1.4 percentage points below it; low and high end bracket the measured number.
By their numbers in this assay, from the lowest: compounds 3, 1, 4 and 2 (each within the scatter of the next).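

In this assay, putting carbamoyl in place of the group of 6 heavy atoms, on a saturated chain carbon, two bonds along the chain from an amide-type nitrogen and a carbonyl carbon, gives a number 1.2 percentage points higher from compound 1 to compound 4 (within the scatter). At this position, then, the read-out does not separate these two side chains, even though the entering group has fewer heavy atoms and fewer hydrogen-bond donors than the one that leaves. The one earlier step within the side chain joined two compounds with a free carboxylic acid, whereas this one joins two benzyl esters, and no measurement shown here gives a reason for the result.

The compounds shown contain no pair that differs only in having the free carboxylic acid or the benzyl ester, so the effect of that exchange on its own stays open. It is also unknown whether a different group at this position, such as a simple primary amine or a longer chain ending in carbamoyl, would give a step beyond the scatter, since every step read so far lies within it.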